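The source may hold more compounds than are shown below. What is called first, only, known or untested is meant among the compounds shown, and "the series" means these compounds.

Series notes. Compound 1 `O=c1c(O)cccn1Cc1ccc(-c2ccccc2)cc1` is the parent of the set. In an ADME assay on THP-1 cells (Homo sapiens) for cytotoxicity, read by resazurin assay, with a stated time of 48 h (a higher number here means a weaker inhibitor, a lower number a stronger inhibitor), compound 1 gives only a limit, > 10 ug/mL. Compound 2 `CN(C)c1ccc(-c2ccc(Cn3cccc(O)c3=O)cc2)cc1` carries dimethylamino in place of hydrogen on an aromatic carbon on the shared core of compound 1. In this assay compound 2 likewise gives only a limit, > 10 ug/mL. The two limits leave the step unreadable: a step that the two limits leave unreadable from compound 1 to compound 2. Compound 3 `O=c1c(O)cccn1Cc1cn(-c2ccccc2)nn1` has a different core; the difference between the two cores is not broken down here. In this assay compound 3 gives only a limit, > 10 ug/mL. Going by the values given here, every value so far sits at the limit of > 10 ug/mL in this assay, at which 3 of the 3 values shown sit.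

Compound 4 `CN(C)c1ccc(-n2cc(Cn3cccc(O)c3=O)nn2)cc1` is not yet measured. Relative to compound 3 it carries dimethylamino in place of hydrogen on an aromatic carbon, the same change, at the same kind of place, as that made between compound 1 and compound 2; the change occurs twice among the compounds shown.

For compound 4 the expected step in this assay is a step that the limit leaves unreadable from compound 3 to compound 4, a small one, because the earlier identical change gave no readable movement and all three values sit at the limit of > 10 ug/mL in this assay, at which 3 of the 3 values shown sit. The estimate for compound 4 in this assay is 15 ug/mL, expected to fall between 5 ug/mL and 50 ug/mL, most likely reported again as a limit.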

Compound 4, half-maximal inhibitory concentration: > 10 ug/mL
Compound 4: only a limit was reported; the forecaster's own chance of this, stated with the estimate: 85%; the middle value is on the limit's open side.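

In this assay compound 4 gives only a limit, > 10 ug/mL; compound 3 also gives only a limit, and no step can be read between compound 3 and compound 4. The whole series stands at one limit: the limit of > 10 ug/mL in this assay, at which 4 of the 4 values shown sit.

The compounds shown leave open how far any of them lies from that limit, and whether dimethylamino in place of hydrogen on an aromatic carbon shifts the read-out at all.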